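From Fluoro to Chloro: Cytotoxicity Outlook for Compound 4

This account rests on a few compounds, and the source may have more. Where it says the series, first, only, none or still open, it means among the compounds named here.

Compound 1 `O=C(/C=C/c1ccc2c(c1)B(O)OC2)c1ccco1` gives in an ADME assay on L929 cells (Mus musculus) for cytotoxicity, read by resazurin assay, with a stated time of 72 h (a higher number here means a weaker inhibitor, a lower number a stronger inhibitor), a limit of > 10 ug/mL.
Compound 2 `COc1ccc(C(=O)/C=C/c2ccc3c(c2)B(O)OC3)cc1` gives in this assay a limit of > 10 ug/mL.
Compound 3 `O=C(/C=C/c1ccc2c(c1)B(O)OC2)c1ccc(F)cc1` gives in this assay a limit of > 10 ug/mL.

Compound 3 therefore stands at the assay limit, the same limit at which every value shown sits (the limit of > 10 ug/mL in this assay, at which 3 of the 3 values shown sit). The change to compound 4 `O=C(/C=C/c1ccc2c(c1)B(O)OC2)c1ccc(Cl)cc1` is chloro in place of fluoro on an aromatic carbon. Two measured steps lead into compound 3: a step that the two limits leave unreadable from compound 1 to compound 3 and a step that the two limits leave unreadable from compound 2 to compound 3. Both run between two limits, so their sizes cannot be read, and neither gives a measured direction for a further change on that aromatic carbon. No step beyond the scatter is expected in this assay. Compound 4 is expected to give about 20 ug/mL, in a range from 8 ug/mL to 60 ug/mL, which means an expected step that the limit leaves unreadable from compound 3 to compound 4.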

Compound 4, half-maximal inhibitory concentration: > 10 ug/mL
Compound 4: no number, only a limit; the forecaster's own chance of this, stated with the estimate: 85%; the middle value is on the limit's open side.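

Compound 4, like compound 1, compound 2 and compound 3, gives only a limit in this assay, so no step among these compounds can be read: the limit of > 10 ug/mL in this assay, at which 4 of the 4 values shown sit.

The compounds shown leave open how far each lies from that limit, and whether any of these changes alters cytotoxicity in this assay at all.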